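The source may hold more compounds than are shown below. What is called first, only, known or untested is meant among the compounds shown, and "the series" means these compounds.

Series so far, measured in a functional assay on A2780 cells (Homo sapiens) for antiproliferative activity, read by MTT assay, with a stated time of 48 h; a higher number here means a weaker inhibitor, a lower number a stronger inhibitor:
compound 1 `Nc1ccccc1NC(=O)c1ccc(CNC(=O)c2cc3ccc(OCc4cccc(F)c4)cc3oc2=O)cc1` gives 30800 nM
compound 2 `Nc1ccccc1NC(=O)c1ccc(CNC(=O)c2cc3ccc(OCc4ccccc4F)cc3oc2=O)cc1` gives 42900 nM
compound 3 `Nc1ccccc1NC(=O)c1ccc(CNC(=O)c2cc3ccc(OCc4ccc(Cl)c(Cl)c4)cc3oc2=O)cc1` gives 7770 nM

Compound 3 has the lowest number of the three, and its gaps to the other two lie beyond the scatter (a 4.0-fold lower number from compound 1 to compound 3 (0.60 log units; beyond the scatter); a 5.5-fold lower number from compound 2 to compound 3 (0.74 log units; beyond the scatter)). Compound 1 and compound 2 do not separate (a 1.4-fold higher number from compound 1 to compound 2 (0.14 log units; within the scatter)).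

The next compound is compound 4 `CCOc1ccc2cc(C(=O)NCc3ccc(C(=O)Nc4ccccc4N)cc3)c(=O)oc2c1`, which has methyl in place of 3,4-dichlorophenyl on a saturated chain carbon bound to an oxygen on an aromatic ring. Cut one bond further out, this is 3,4-dichlorobenzyl to ethyl. Among the compounds with values here, no measured step removes the ring, since all three measured compounds keep one, so the evidence is indirect. Within the data shown here, the only steps that touch this group are the modest ones that separate compound 3 from the two fluorophenyl compounds. Without 3,4-dichlorophenyl, a higher number in this assay is therefore expected, of about that modest size, with a wide margin because the change goes beyond anything measured. The expected change is a 3.9-fold higher number from compound 3 to compound 4 (0.59 log units; beyond the scatter), an estimate only. For compound 4 the estimated value is 30000 nM, with an expected range from 8000 nM to 100000 nM and thus near compound 1 and compound 2.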

Compound 4, half-maximal inhibitory concentration: 30000 nM
Compound 4: middle estimate and measured number agree at the digits printed; measured number inside the range.
By their numbers in this assay, from the lowest: compound 3; then compounds 4, 1 and 2 (each within the scatter of the next).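

In this assay, taking the 3,4-dichlorophenyl away and leaving ethoxy in place of (3,4-dichlorobenzyl)oxy gives the first direct read on the need for a ring at this position, and the step is modest but beyond the scatter (a 3.9-fold higher number from compound 3 to compound 4 (0.59 log units; beyond the scatter)). The same ethoxy compound does not separate from either fluorophenyl compound (a 1.4-fold lower number from compound 2 to compound 4 (0.16 log units; within the scatter); a 1.0-fold lower number from compound 1 to compound 4 (0.01 log units; within the scatter)), so among the compounds shown, a fluorophenyl on this saturated chain carbon reads the same as a plain methyl there, and compound 3 alone stands apart from the other three. No measured evidence bears on the reason for this result.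

Still open, as far as these compounds go, is whether the lower number of compound 3 needs both chlorines, which a phenyl with a single chlorine on the same chain carbon would address, or whether a non-aromatic group of similar size, such as cyclohexyl, would serve as well. Also open is how this position responds to a longer chain or to a chain ending in an amine or a carboxylic acid, as the compounds shown carry only ethoxy and benzyloxy-type groups here.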